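A few compounds are considered here, and "the series" means these few. Any claim that something is new, unique, unknown or untested is made for them only; others in the source may bear on it.

Measured compounds:
Compound 1, `COc1ccc(Nc2cncc(N3CC4CC(C3)N4)c2)cc1`: 2.2 nM
Compound 2, `Clc1ccc(Nc2cncc(N3CC4CC(C3)N4)c2)cc1`: 1.2 nM
Compound 3, `O=[N+]([O-])c1ccc(Nc2cncc(N3CC4CC(C3)N4)c2)cc1`: 0.684 nM

All three share one core and differ only in a single group on an aromatic carbon, and all three were tested in an assay on HEK293 cells for displacement of a labelled ligand from Neuronal acetylcholine receptor; alpha3/beta4 (Homo sapiens); a lower number here means a stronger inhibitor, a higher number a weaker inhibitor. Compound 3 gives the lowest number of the three. The step of a 1.8-fold lower number from compound 2 to compound 3 (0.24 log units; within the scatter) lies within the scatter, so compound 3 is not firmly separated from compound 2; the step of a 3.2-fold lower number from compound 1 to compound 3 (0.51 log units; beyond the scatter) lies beyond it, so the separation from compound 1 is real, though modest.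

Compound 4, `FC(F)(F)c1ccc(Nc2cncc(N3CC4CC(C3)N4)c2)cc1`, has not yet been measured. The change from compound 3 is trifluoromethyl in place of nitro on an aromatic carbon. The three measured steps all swap one group at this same place: a 1.8-fold lower number from compound 1 to compound 2 (0.26 log units; within the scatter), a 3.2-fold lower number from compound 1 to compound 3 (0.51 log units; beyond the scatter) and a 1.8-fold lower number from compound 2 to compound 3 (0.24 log units; within the scatter). Among the measured compounds shown here, none of these swaps moved the number by more than a modest amount, and trifluoromethyl was not among the groups tried, so no step speaks to it directly. The best guide is that chloro and nitro sit within the scatter of each other. For compound 4 the expected step is a 1.5-fold higher number from compound 3 to compound 4 (0.16 log units; within the scatter), which need not exceed the scatter. The estimate for compound 4 in this assay is 1 nM, with a range from 0.4 nM to 2.5 nM.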

Compound 4, inhibition constant: 1.02 nM
Compound 4: the middle estimate sits 1.0-fold (0.01 log units) below what was measured; the range from low to high includes it.
By their numbers in this assay, from the lowest: compounds 3, 4, 2 and 1 (each within the scatter of the next, the first and the last beyond it).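

In this assay, trifluoromethyl cannot be separated from the groups it was compared with, as both the swap for nitro (with a 1.5-fold higher number from compound 3 to compound 4 (0.17 log units; within the scatter)) and the swap for chloro (with a 1.2-fold lower number from compound 2 to compound 4 (0.07 log units; within the scatter)) stay within the scatter, even though nitro carries 2 hydrogen-bond acceptors and trifluoromethyl carries 0. Methoxy now stands apart from a second group, with a 2.2-fold lower number from compound 1 to compound 4 (0.33 log units; beyond the scatter) being a modest step beyond the scatter, so compound 1 is separated from compound 3 and compound 4 but still not from compound 2, which goes against any clean split between methoxy and the other three groups. The compounds shown offer nothing that explains these small differences.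

Going by these compounds, all four groups leave the number within a narrow span, so it remains open whether this place would stay as forgiving with an amine, a carboxylic acid or a longer chain such as butyl. On these data alone, it is also open whether the same swaps would give the same small steps on another carbon of this aromatic ring, or with a change elsewhere in the shared core.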